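The compounds below may be only part of what the source reports. "The series", "measured", "known", "first", "only" and "open" are said of these compounds alone.

Measured in a functional assay on Malme-3M cells (Homo sapiens) for cytotoxicity, read by MTT assay, with a stated time of 6 days; a lower number here means that less compound is needed, a higher number that more compound is needed for the effect:
- compound 1 `COC(=O)c1c(-c2ccc(O)cc2)oc2ccccc2c1=O` gives > 25 ug/mL, a limit of the assay, not a number.
- compound 2 `COC(=O)c1c(-c2ccc(O)cc2)oc2ccc(OC)cc2c1=O` gives > 25 ug/mL, likewise a limit.
- compound 3 `COc1ccc2c(=O)cc(-c3cc(OC)c(OC)c(OC)c3)oc2c1` gives > 25 ug/mL, also a limit.

Compound 2 differs from compound 1 by methoxy in place of hydrogen on an aromatic carbon. Both ends of a step that the two limits leave unreadable from compound 1 to compound 2 sit at the limit of > 25 ug/mL in this assay, at which 3 of the 3 values shown sit, so its size is not readable. The difference between the core of compound 1 and the core of compound 3 is not broken down here.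

Compound 4 `COc1cc(-c2cc(=O)c3ccc(OC)c(OC)c3o2)cc(OC)c1OC` is not yet measured. It carries methoxy in place of hydrogen on an aromatic carbon, the same kind of change as from compound 1 to compound 2, but the place differs: here the entering methoxy is ortho to a fused ring and ortho to a methoxy group, there it was para to a fused ring.

With the measured step unreadable, compound 4 is expected to stay near the limit of compound 3 in this assay, an expected step that the limit leaves unreadable from compound 3 to compound 4. The estimate for compound 4 is 30 ug/mL, between 12 ug/mL and 80 ug/mL.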

Compound 4, concentration for half-maximal effect: > 25 ug/mL
Compound 4: only a limit was reported; the forecaster's own chance of this, stated with the estimate: 70%; the middle value does not contradict the limit.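

Compound 3 and compound 4 both sit at a limit of the assay, so the step between them cannot be read: the limit of > 25 ug/mL in this assay, at which 4 of the 4 values shown sit.

The compounds shown leave open whether methoxy in place of hydrogen on an aromatic carbon changes the result in this assay at all.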